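The source may report more compounds than this note shows. Statements on the series, on what has been measured and on what is new or still open speak of the compounds shown alone.

Compound 1, `CC(=O)n1cc(/C=C(/C(=O)O)c2ccccc2)c2cc(OCc3ccccc3)ccc21`, in a functional assay on DU-145 cells (Homo sapiens) for cytotoxicity, read by MTT assay, with a stated time of 72 h (on this read-out lower numbers stand for stronger inhibition and higher numbers for weaker inhibition), compound 1 gives 26700 nM.
Compound 2, `COc1ccc(Cn2cc(/C=C(/C(=O)O)c3ccccc3)c3cc(OCc4ccccc4)ccc32)cc1`, in this assay compound 2 gives 860 nM.

Among the two compounds measured, compound 2 stands with the lowest number; its nearest neighbour is compound 1, which lies well beyond the scatter from it. Among the measured compounds shown here, the only measured step, a 31-fold lower number from compound 1 to compound 2 (1.49 log units; beyond the scatter), shows that what sits on the aromatic nitrogen of the shared core weighs heavily in this assay.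

Compound 3, `O=C(O)/C(=C/c1c[nH]c2ccc(OCc3ccccc3)cc12)c1ccccc1`, differs from compound 2 in one place: hydrogen in place of 4-methoxybenzyl on an aromatic nitrogen. For the measured compounds named here, the one measured step bears on this change only indirectly, since it exchanged one substituent for another rather than removing one. It does suggest that a substituent on that nitrogen matters, so compound 3 is expected to give a higher number than compound 2, with a 9.3-fold higher number from compound 2 to compound 3 (0.97 log units; beyond the scatter) as the estimated step. For compound 3 the expected value is 8000 nM, with a range from 1500 nM to 40000 nM.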

Compound 3, half-maximal inhibitory concentration: 34700 nM
Estimate against measurement, compound 3: 4.3-fold (0.64 log units) below; low and high end bracket the measured number.
By their numbers in this assay, from the lowest: compound 2; then compounds 1 and 3 (each within the scatter of the next).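

Taking the 4-methoxybenzyl group off the aromatic nitrogen in this assay gives a 40-fold higher number from compound 2 to compound 3 (1.61 log units; beyond the scatter) and returns the number to the level of the acetyl compound. Acetyl and hydrogen on that nitrogen cannot be told apart, with a 1.3-fold higher number from compound 1 to compound 3 (0.11 log units; within the scatter) as their step, so the earlier drop is a gain tied to 4-methoxybenzyl rather than a penalty tied to acetyl. No measurement shown here explains why this group makes such a difference.

The compounds shown leave open whether the gain needs the whole 4-methoxybenzyl group or would survive with a plain benzyl or a 4-hydroxybenzyl group. They also do not say how a small methyl group or a longer chain such as phenethyl on that nitrogen would compare.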